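This account rests on a few compounds, and the source may have more. Where it says the series, first, only, none or still open, it means among the compounds named here.

In an ADME assay on microsomes from liver (Mus musculus) for metabolic stability, with a stated time of 10 min, tested at 0.5 uM (on this read-out lower numbers stand for a less stable compound and higher numbers for a more stable compound), compound 2 (`CCC(c1nc2ccc(Cl)cc2[nH]1)[C@H]1CC[C@@H](c2ccnc3ccc(F)cc32)CC1`) gives 49%. That number lies within the usual scatter of compound 1 (`CCC(c1nc2ncc(Cl)cc2[nH]1)[C@H]1CC[C@@H](c2ccnc3ccc(C(F)(F)F)cc32)CC1`) at 57%, so these two cannot be told apart. Compound 3 (`C[C@@H](c1nnc(-c2ccc(Cl)cc2)[nH]1)[C@H]1CC[C@@H](c2ccnc3ccc(F)cc32)CC1`) reaches 69%, which is beyond the scatter from compound 2.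

Compound 4 (`CCC(c1nc2ncc(Cl)cc2[nH]1)[C@H]1CC[C@@H](c2ccnc3ccc(F)cc32)CC1`) has not yet been measured. It differs from compound 2 in one place: a group of 10 heavy atoms (6 carbon, 3 nitrogen, 1 chlorine; one five-membered aromatic ring with 2 hetero atoms, one six-membered aromatic ring with 1 hetero atom) in place of a group of 10 heavy atoms (7 carbon, 2 nitrogen, 1 chlorine; one five-membered aromatic ring with 2 hetero atoms, one six-membered aromatic ring of carbon only), on a saturated chain carbon bound to a saturated chain carbon and a saturated ring carbon. Put simply, a six-membered aromatic ring with 1 hetero atom takes the place of a six-membered aromatic ring of carbon only.

Among the compounds with values here, no measured pair shows this change on its own, so the forecast rests on thin evidence. Compound 1 already carries the entering group, and its 57% offers the closest guide, although it is not a clean comparison. A small rise in this assay, within the scatter, is therefore expected, and the estimate is a number 5 percentage points higher from compound 2 to compound 4 (within the scatter). For compound 4, the expected value is 54%, with an estimated range from 41% to 67%.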

Compound 4, percent of the compound remaining: 7%
For compound 4 the middle estimate is 47 percentage points above the measured one, outside the stated range (below it).
By their numbers in this assay, from the lowest: compound 4; then compounds 2 and 1 (each within the scatter of the next); then compound 3.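

In this assay, the chain carbon turns out to be highly sensitive to a single ring change: a six-membered aromatic ring with 1 hetero atom in place of one of carbon only gives a number 42 percentage points lower from compound 2 to compound 4 (beyond the scatter). That entering group does not set the outcome alone, since compound 1 carries it too, and fluoro in place of trifluoromethyl on an aromatic carbon gives a number 50 percentage points lower from compound 1 to compound 4 (beyond the scatter), so the two changes must be read together. No measurement here explains why either step is so large.

As far as these compounds go, it remains open what trifluoromethyl would do alongside the carbon-only ring of compound 2, and so whether it matters only with the entering group. From the compounds shown here alone, it is equally open how a nitrile or a methoxy group would behave on that same aromatic carbon.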